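The compounds below may be only part of what the source reports. "The series", "measured", "known", "first", "only" and "open" are said of these compounds alone.

Compound 1, `Nc1nc(Cl)c(-c2ccccn2)c(N[C@@H]2C[C@H](CO)[C@@H](O)[C@H]2O)n1`: in an ADME assay on cells (Homo sapiens) for cytotoxicity, read by polymerase chain reaction, with a stated time of 3 days (a lower number here means that less compound is tolerated, a higher number that more compound is tolerated), compound 1 gives only a limit, > 25000 nM.
Compound 2, `Nc1nc(Cl)c(-c2ncco2)c(N[C@@H]2C[C@H](CO)[C@@H](O)[C@H]2O)n1`: in this assay compound 2 gives only a limit, > 25000 nM.
Compound 3, `Cc1nc(NC(C)(C)C)nc(N[C@@H]2C[C@H](CO)[C@@H](O)[C@H]2O)c1-c1nc2ccccc2s1`: in this assay compound 3 gives 12000 nM.

Within the data shown here, the one step measured so far, a step that the two limits leave unreadable from compound 1 to compound 2, cannot be read because of the limit of > 25000 nM in this assay, at which 2 of the 3 values shown sit. Among the measured compounds shown here, compound 3 thus stands as the only real number among the three values shown.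

Compound 4, `Cc1nc(Nc2ccccc2)nc(N[C@@H]2C[C@H](CO)[C@@H](O)[C@H]2O)c1-c1nc2ccccc2s1`, differs from compound 3 in one place: phenyl in place of tert-butyl on a nitrogen on an aromatic ring. For the measured compounds named here, no measured step touches this kind of change, and the single measured step gives no size to lean on. The expectation is therefore a step of no clear direction and within the scatter, no change at the digits printed from compound 3 to compound 4 (within the scatter). Compound 4 is estimated at 12000 nM in this assay, between 4000 nM and 25000 nM.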

Compound 4, half-maximal cytotoxic concentration: > 25000 nM
Compound 4: no number, only a limit (the forecaster's own chance of this, stated with the estimate: 35%); middle value at least 2.0-fold (0.31 log units) away from the limit.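

In this assay, phenyl in place of tert-butyl on this nitrogen gives an at least 2.0-fold higher number from compound 3 to compound 4 (0.31 log units; beyond the scatter), the first readable step shown, so the group on this nitrogen can shift the tolerated concentration. Compound 4 gives > 25000 nM, which is a limit and not a number, so the step has a direction but no upper size. Only compound 3 keeps a real number: the limit of > 25000 nM in this assay, at which 3 of the 4 values shown sit.

A cyclohexyl group on this nitrogen would help show whether the aromatic ring itself matters. Going by these compounds, how a longer carbon chain would behave here also remains open.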